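The source may report more compounds than this note shows. Statements on the series, on what has been measured and on what is new or still open speak of the compounds shown alone.

Compound 1 `O=C(CCCCCCc1ccccc1)c1nc(C(F)(F)F)co1`: 214 nM. Compound 2 `O=C(CCCCCCc1ccccc1)c1nc(Cl)co1`: 2400 nM. Compound 3 `CSc1coc(C(=O)CCCCCCc2ccccc2)n1`: > 10000 nM.

In an assay on HEK-293T cells for inhibition of diacylglycerol lipase-alpha (Homo sapiens), read by colorimetric assay (a lower number here means a stronger inhibitor, a higher number a weaker inhibitor), compound 1 gives 214 nM and compound 2 gives 2400 nM. For compound 3 the figure > 10000 nM is a limit of this assay and not a number, as recorded in the limit of > 10000 nM in this assay, at which 1 of the 3 values shown sits. Compound 3 thus stands as the weakest of the three. Compound 4 `O=C(CCCCCCc1ccccc1)c1nc(-c2ccccc2)co1` differs from it by phenyl in place of methylsulfanyl on an aromatic carbon. Every earlier change at this carbon moved the number strongly: an 11-fold higher number from compound 1 to compound 2 (1.05 log units; beyond the scatter), an at least 46-fold higher number from compound 1 to compound 3 (1.66 log units; beyond the scatter) and an at least 4.1-fold higher number from compound 2 to compound 3 (0.61 log units; beyond the scatter). Among the measured compounds shown here, the group here clearly matters, yet no measured step shows how a phenyl behaves. Compound 4 is expected to fall at about 3000 nM, between 400 nM and 15000 nM. That estimate means an at least 3.3-fold lower number from compound 3 to compound 4 (0.52 log units; beyond the scatter).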

Compound 4, half-maximal inhibitory concentration: 8710 nM
Estimate against measurement, compound 4: 2.9-fold (0.46 log units) below; low and high end bracket the measured number.
By their numbers in this assay, from the lowest: compound 1; then compound 2; then compound 4. At a limit, above all of these: compound 3.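

In this assay, phenyl on this aromatic carbon does worse than either trifluoromethyl or chloro: the change gives a 41-fold higher number from compound 1 to compound 4 (1.61 log units; beyond the scatter) and a 3.6-fold higher number from compound 2 to compound 4 (0.56 log units; beyond the scatter). Compound 3 carries a limit and not a number: the limit of > 10000 nM in this assay, at which 1 of the 4 values shown sits. The step against it is therefore only a floor, an at least 1.1-fold lower number from compound 3 to compound 4 (0.05 log units; that floor lies within the scatter), so whether phenyl does better than methylsulfanyl cannot be read.

The compounds shown leave open how an amine, a nitrile or a methyl group on this carbon would rank against trifluoromethyl. They also leave open whether a fluorine on the phenyl would change its standing.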